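This account rests on a few compounds, and the source may have more. Where it says the series, first, only, none or still open, it means among the compounds named here.

Measured compounds:
- compound 1 `CCOc1nc2cccc(C(=O)Nc3ccc(OC)cc3)c2n1Cc1ccc(-c2ccccc2-c2nnn[nH]2)cc1` gives 25.8% in an assay on isolated protein for inhibition of NEDD8-activating enzyme E1 regulatory subunit (Homo sapiens), read by Western blot, with stated times of 10 min and 30 min, tested at 25 uM; a higher number here means more inhibition at the concentration tested (going by the name of the read-out), a lower number less inhibition
- compound 2 `CCOc1nc2cccc(C(=O)Nc3ccc(S(N)(=O)=O)cc3)c2n1Cc1ccc(-c2ccccc2-c2nnn[nH]2)cc1` gives 60.9% in this assay
- compound 3 `CCOc1nc2cccc(C(=O)NCc3ccco3)c2n1Cc1ccc(-c2ccccc2-c2nnn[nH]2)cc1` gives 37.5% in this assay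

Compound 3 stands second highest of the three: the step of a number 11.7 percentage points higher from compound 1 to compound 3 (beyond the scatter) places it beyond the scatter above compound 1, while the step of a number 23.4 percentage points lower from compound 2 to compound 3 (beyond the scatter) leaves it clearly below compound 2. Compound 4 `CCOc1nc2cccc(C(=O)NOCc3ccccc3)c2n1Cc1ccc(-c2ccccc2-c2nnn[nH]2)cc1` has not been measured. The change is benzyloxy in place of (furan-2-yl)methyl on an amide-type nitrogen. Within the data shown here, both earlier changes on this amide-type nitrogen, a number 11.7 percentage points higher from compound 1 to compound 3 (beyond the scatter) and a number 23.4 percentage points lower from compound 2 to compound 3 (beyond the scatter), were modest, and no measured pair shows the benzyloxy group itself. A small shift, possibly within the scatter, is therefore expected: a number 2.5 percentage points lower from compound 3 to compound 4 (within the scatter). Compound 4 is estimated at 35%, with a range from 20% to 55%.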

Compound 4, a percentage reported as inhibition, at one concentration (the size of the read-out at that concentration, not a potency): 39.8%
Beside the measured number, compound 4's estimate is 4.8 percentage points below it, within the range that was stated.
By their numbers in this assay, from the lowest: compound 1; then compounds 3 and 4 (each within the scatter of the next); then compound 2.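

In this assay, benzyloxy in place of (furan-2-yl)methyl on the amide-type nitrogen gives a number 2.3 percentage points higher from compound 3 to compound 4 (within the scatter), so this nitrogen can carry a group attached through oxygen with no readable change. Compound 4 also sits apart from both compounds with a ring directly on that nitrogen, with a number 14 percentage points higher from compound 1 to compound 4 (beyond the scatter) and a number 21.1 percentage points lower from compound 2 to compound 4 (beyond the scatter), leaving the 4-sulfamoylphenyl compound clearly highest. No supporting evidence accounts for these numbers. Still open, going by these compounds, is whether a plain benzyl group would read like benzyloxy, and whether a carboxylic acid in place of the sulfamoyl would hold the level of compound 2.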